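Pyridin-3-yl for pyrazol-4-yl in a fused series

The source may report more compounds than this note shows. Statements on the series, on what has been measured and on what is new or still open speak of the compounds shown alone.

Compound 1 `c1cc(-c2cn[nH]c2)c2c(c1)C(c1ncc[nH]1)CC2` is the starting point of this comparison. In a functional assay on CHO cells for agonist activity at Alpha-1B adrenergic receptor (Homo sapiens), read by FLIPR and calcium flux (a higher number here means that more compound is needed for the effect, a lower number that less compound is needed), compound 1 gives only a limit of the assay, > 10000 nM. Compound 2 `Cc1c(OCC2=NCCN2)ccc(Cl)c1NS(C)(=O)=O` belongs to a different scaffold and in this assay gives likewise a limit, > 10000 nM. Compound 3 `Clc1ccc2c(c1-c1cn[nH]c1)CCC2c1ncc[nH]1` differs from compound 1 by chloro in place of hydrogen on an aromatic carbon. In this assay compound 3 also gives a limit, > 10000 nM. Hence compound 1 stands nowhere on a numeric scale: all three values shown sit at the limit of > 10000 nM in this assay, at which 3 of the 3 values shown sit, and the one single-change step, a step that the two limits leave unreadable from compound 1 to compound 3, cannot be read.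

Compound 4 `c1cncc(-c2cccc3c2CCC3c2ncc[nH]2)c1` is the next single change from compound 1: pyridin-3-yl in place of 1H-pyrazol-4-yl on an aromatic carbon. Among the measured compounds shown here, no measured step bears on this kind of change, and the only step in the set is unreadable, so no direction can be drawn from the data. With the nearest relatives of compound 4 all sitting at the assay limit, the expected outcome is another limit rather than a number. Compound 4 is therefore estimated at 15000 nM, with a range from 5000 nM to 60000 nM. The step that the limit leaves unreadable from compound 1 to compound 4 is thus expected to be essentially none beyond the scatter, most likely unreadable again.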

Compound 4, half-maximal effective concentration: > 10000 nM
Compound 4: only a limit was reported (the forecaster's own chance of this, stated with the estimate: 85%); the middle value lies beyond the limit too.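

The step from compound 1 to compound 4 cannot be read, as both compounds give only a limit in this assay: the limit of > 10000 nM in this assay, at which 4 of the 4 values shown sit.

The compounds shown give no numeric value, which leaves open whether either change on the shared core, chloro or pyridin-3-yl, moves the half-maximal effective concentration in any direction.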